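From methoxycarbonyl to (dimethylsulfamoyl)methyl on the shared core

The compounds below may be only part of what the source reports. "The series", "measured", "known", "first", "only" and "open" are said of these compounds alone.

Measured compounds in a functional assay on the whole organism with Rattus norvegicus as the target; a lower number here means that less compound is needed, a higher number that more compound is needed for the effect
- Compound 1 `Cn1c(=N)sc2cc(OC(F)(F)F)ccc21` gives 5 mg/kg
- Compound 2 `N=c1sc2cc(OC(F)(F)F)ccc2n1Cc1ccccc1` gives > 10 mg/kg, a limit of the assay
- Compound 3 `COC(=O)Cn1c(=N)sc2cc(OC(F)(F)F)ccc21` gives > 10 mg/kg, a limit of the assay

Compound 3 thus stands without a number, and its entry is a limit. The same holds for compound 2, and the series as a whole shows (the limit of > 10 mg/kg in this assay, at which 2 of the 3 values shown sit).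

Compound 4 `CN(C)S(=O)(=O)CCn1c(=N)sc2cc(OC(F)(F)F)ccc21` carries (dimethylsulfamoyl)methyl in place of methoxycarbonyl on a saturated chain carbon bound to an aromatic nitrogen.

Two measured steps change that same carbon. They are an at least 2.0-fold higher number from compound 1 to compound 2 (0.30 log units; that floor lies within the scatter) and an at least 2.0-fold higher number from compound 1 to compound 3 (0.30 log units; that floor lies within the scatter). Each gives only a floor, and neither floor is shown beyond the scatter. The comparison a step that the two limits leave unreadable from compound 2 to compound 3 cannot be read, so the two groups cannot be ranked. Within the data shown here, no measured compound carries the entering group.

Given an at least 2.0-fold higher number from compound 1 to compound 3 (0.30 log units; that floor lies within the scatter), compound 4 is expected to stay close to the limit of this assay, and a report of a limit alone is likely. No step beyond the scatter is expected in either direction, and the estimated step is a step that the limit leaves unreadable from compound 3 to compound 4. For compound 4 the expected value is 12 mg/kg, with an estimated range from 4 mg/kg to 35 mg/kg.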

Compound 4, dose for half-maximal effect: > 10 mg/kg
Compound 4 gave a limit, no number; the forecaster's own chance of this, stated with the estimate: 65%; the middle value lies beyond the limit too.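

In this assay a third group on a saturated chain carbon bound to an aromatic nitrogen, (dimethylsulfamoyl)methyl, ends at a limit just as phenyl and methoxycarbonyl did, and this widens the picture of the series: the limit of > 10 mg/kg in this assay, at which 3 of the 4 values shown sit.

Among these compounds, the only step that can be read is an at least 2.0-fold higher number from compound 1 to compound 4 (0.30 log units; that floor lies within the scatter), the same kind of floor as the two earlier replacements of hydrogen gave. The steps among the three compounds that end at a limit cannot be read, so (dimethylsulfamoyl)methyl, methoxycarbonyl and phenyl cannot be ranked against one another.

As far as these compounds go, only compound 1 carries a number, so how far any of the three other compounds lies from it stays open. From the compounds shown here alone, whether a carboxylic acid or an amine at this place would give a number in this assay also stays open.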